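A Chloro Group Added to Compound 1

A few compounds are considered here, and "the series" means these few. Any claim that something is new, unique, unknown or untested is made for them only; others in the source may bear on it.

In a functional assay on MCF7 cells (Homo sapiens) for antiproliferative activity, read by MTT assay, with a stated time of 48 h (a lower number here means a stronger inhibitor, a higher number a weaker inhibitor), compound 1 `N=C(N)N/N=C(/C=C/c1ccccc1)c1ccccc1` gives 17000 nM and compound 2 `COc1ccc(/C=C/C(=N/NC(=N)N)c2ccccc2)cc1` gives 14000 nM, so the two values stand within the scatter of each other. Compound 3 `N=C(N)N/N=C(/C=C/c1ccccc1Cl)c1ccccc1` carries chloro in place of hydrogen on an aromatic carbon of compound 1, ortho to a large group (chloro in place of hydrogen on an aromatic carbon). Among the compounds with values here, the one measured step that bears on this change, methoxy in place of hydrogen on an aromatic carbon, is a 1.2-fold lower number from compound 1 to compound 2 (0.08 log units; within the scatter). On that single precedent, no step beyond the scatter is expected in this assay, in either direction. For compound 3 the estimated value is 13000 nM, with an expected range from 6000 nM to 27000 nM.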

Compound 3, half-maximal inhibitory concentration: 4200 nM
Compound 3: middle estimate off by 3.1-fold (0.49 log units), on the high side; measured number outside the range, below it.
By their numbers in this assay, from the lowest: compound 3; then compounds 2 and 1 (each within the scatter of the next).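

In this assay, chloro in place of hydrogen on an aromatic carbon, ortho to a large group, gives a 4.0-fold lower number from compound 1 to compound 3 (0.61 log units; beyond the scatter), a modest step beyond the scatter. So the change from phenyl to 2-chlorophenyl shows that a single added atom at this position can move the number beyond the scatter, which the methoxy step, a 1.2-fold lower number from compound 1 to compound 2 (0.08 log units; within the scatter), did not show. Nothing measured here accounts for this step.

As far as these compounds go, whether fluoro, methyl or an amine at this position would lower the number as far remains open. So does whether chloro elsewhere on the same ring would do so.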